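Benzyl variation on the shared core: compound 3 expected

A few compounds are considered here, and "the series" means these few. Any claim that something is new, unique, unknown or untested is made for them only; others in the source may bear on it.

Compound 1 `O=c1ccoc2cc(OCc3cn(Cc4ccc(Cl)cc4Cl)nn3)ccc12` carries 2,4-dichlorophenyl on a saturated chain carbon bound to an aromatic nitrogen, and in a functional assay on HeLa cells (Homo sapiens) for cytotoxicity, read by MTT assay, with a stated time of 48 h (on this read-out higher numbers stand for weaker inhibition and lower numbers for stronger inhibition), compound 1 gives 80600 nM. Compound 2 `N#Cc1cccc(Cn2cc(COc3ccc4c(=O)ccoc4c3)nn2)c1` carries 3-cyanophenyl at that place. In this assay compound 2 reaches only a limit of the assay, > 100000 nM, so no number is known for it. That limit is the limit of > 100000 nM in this assay, at which 1 of the 2 values shown sits. For the measured compounds named here, the one measured step, an at least 1.2-fold higher number from compound 1 to compound 2 (0.09 log units; that floor lies within the scatter), therefore says only that compound 2 is not stronger than compound 1, with a floor inside the scatter.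

Compound 3 `COc1ccc(Cn2cc(COc3ccc4c(=O)ccoc4c3)nn2)cc1` differs from compound 2 by 4-methoxyphenyl in place of 3-cyanophenyl on a saturated chain carbon bound to an aromatic nitrogen. Going by the values given here, only the step from compound 1 to compound 2 bears on this change, and it shows no movement beyond the scatter when one benzyl group replaces another at this place; compound 1 and compound 2 both sit at the weak end of this assay. For compound 3 no shift beyond the scatter is expected, a number no higher from compound 2 to compound 3 (the limit leaves the size open). Compound 3 is thus estimated at 100000 nM, in the range 50000 nM to 200000 nM, with a fair chance that this assay again reports only a limit.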

Compound 3, half-maximal inhibitory concentration: 14400 nM
The estimate for compound 3 lay 6.9-fold (0.84 log units) above the measured number; the measured number lies below the stated range.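

The place on a saturated chain carbon bound to an aromatic nitrogen is not silent in this assay: 4-methoxyphenyl gives a 5.6-fold lower number from compound 1 to compound 3 (0.75 log units; beyond the scatter) when it replaces 2,4-dichlorophenyl, and an at least 6.9-fold lower number from compound 2 to compound 3 (0.84 log units; beyond the scatter) when it replaces 3-cyanophenyl. The counts do not separate the last two groups, as 3-cyanophenyl and 4-methoxyphenyl each have 8 heavy atoms, one six-membered aromatic ring of carbon only and 1 hydrogen-bond acceptor, so the difference in read-out goes with the identity of the group and not with these counts. Compound 2 is reported only as a limit of the assay, so the step that starts from it gives a floor and not a size: the limit of > 100000 nM in this assay, at which 1 of the 3 values shown sits.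

The compounds shown do not separate the methoxy group itself from its placement on the ring, as each of the three benzyl groups differs from the others in both respects. As far as these compounds go, how an unsubstituted benzyl, a 3-methoxybenzyl, a 4-aminobenzyl or a longer chain carrying the same 4-methoxyphenyl would read at this place remains open.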